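Pyridin-4-yl for 4-chlorophenyl on the thiazole carbon

The compounds below may be only part of what the source reports. "The series", "measured", "known", "first", "only" and "open" are said of these compounds alone.

The measured compounds in a functional assay on cells (Lymphocyte, Homo sapiens); a lower number here means a stronger inhibitor, a higher number a weaker inhibitor:
Compound 1, `Nc1nc(N2CCN(C(=O)COc3ccc(Cl)cc3)CC2)c2nc(CCc3ccc(F)cc3)sc2n1`, 4400 nM
Compound 2, `Nc1nc(N2CCN(C(=O)COc3ccc(Cl)cc3)CC2)c2nc(CCCc3ccc(F)cc3)sc2n1`, 960 nM
Compound 3, `Nc1nc(N2CCN(C(=O)COc3ccc(Cl)cc3)CC2)c2nc(-c3ccc(Cl)cc3)sc2n1`, 270 nM

Compound 3 gives the lowest number of the three in this assay. The nearest measured compound is compound 2, with a 3.6-fold lower number from compound 2 to compound 3 (0.55 log units; beyond the scatter); the furthest is compound 1, with a 16-fold lower number from compound 1 to compound 3 (1.21 log units; beyond the scatter). Between the two chain-linked compounds the step is a 4.6-fold lower number from compound 1 to compound 2 (0.66 log units; beyond the scatter). All three of these steps lie beyond the scatter, so compound 3 stands clearly ahead of compounds 1 and 2 in this assay.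

Compound 4, `Nc1nc(N2CCN(C(=O)COc3ccc(Cl)cc3)CC2)c2nc(-c3ccncc3)sc2n1`, differs from compound 3 in one place: pyridin-4-yl in place of 4-chlorophenyl on an aromatic carbon

Among the measured compounds shown here, none of the measured steps changes a directly attached aromatic ring for another directly attached aromatic ring; the steps from compound 1 and compound 2 to compound 3 only show that a ring placed directly on the five-membered ring gave lower numbers than the chain-linked rings. What the 4-chlorophenyl to pyridin-4-yl exchange does is therefore not anchored by any measured pair. The account expects a modest rise in the number, within a wide range, and estimates compound 4 in this assay at 700 nM, between 180 nM and 2800 nM, which is expected to correspond to a step of a 2.6-fold higher number from compound 3 to compound 4 (0.41 log units; beyond the scatter).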

Compound 4, half-maximal inhibitory concentration: 40 nM
For compound 4 the middle estimate is 18-fold (1.24 log units) above the measured one; the measured number lies below the stated range.
By their numbers in this assay, from the lowest: compound 4; then compound 3; then compound 2; then compound 1.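

In this assay the exchange of 4-chlorophenyl for pyridin-4-yl gives (a 6.8-fold lower number from compound 3 to compound 4 (0.83 log units; beyond the scatter)), which shows that the number at this aromatic carbon of the five-membered ring depends on which directly attached ring is present, and not only on whether the ring is attached directly or through a chain. The new compound also extends the lead over the chain-linked compounds, with large steps of (a 24-fold lower number from compound 2 to compound 4 (1.38 log units; beyond the scatter)) and (a 110-fold lower number from compound 1 to compound 4 (2.04 log units; beyond the scatter)), and its steps to all three others lie beyond the scatter, so compound 4 is the strongest inhibitor of the four in this assay. Nothing available here explains why pyridin-4-yl gives the lower number.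

The exchange removes the chlorine and brings in the ring nitrogen at the same time, so the compounds shown leave open which of the two changes carries the step, a question that an unsubstituted phenyl ring would help to separate. As far as these compounds go, it also remains open whether the place of the ring nitrogen matters, as pyridin-3-yl or pyridin-2-yl at this carbon would show.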